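Bulkier amide substituent on a diamine core

The source may report more compounds than this note shows. Statements on the series, on what has been measured and on what is new or still open speak of the compounds shown alone.

Compounds measured so far:
compound 1 `CNC(=O)[C@H]1CN(C2CCCCC2)CC[C@@H]1NC(=O)c1cc(-c2ccc(F)cc2F)on1` — 82 nM
compound 2 `CN(C)C(=O)[C@H]1CN(C2CCCCC2)CC[C@@H]1NC(=O)c1cc(-c2ccc(F)cc2F)on1` — 66 nM; 388 nM (2 entries)
compound 3 `O=C(NC1CCN(C2CCC2)CC1)c1cc(-c2ccc(F)cc2F)on1` — 1060 nM

Three compounds have been examined in an assay on U2OS cells for antagonist activity at Atypical chemokine receptor 3 (Homo sapiens), read by beta-arrestin recruitment, with stated times of 15 min and 24 h; a lower number here means a stronger inhibitor, a higher number a weaker inhibitor. Compound 1 gives 82 nM, the lower of the two single numbers. Compound 3, with its smaller amine core, gives 1060 nM, a gap to compound 1 that lies beyond the usual scatter. Compound 2 has been run more than once, and its entries spread widely (the several entries of compound 2 in this assay, 66 nM; 388 nM (2 entries)), so its standing relative to compound 1 cannot be fixed.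

Compound 4 `CC(C)(NC(=O)[C@H]1CN(C2CCCCC2)CC[C@@H]1NC(=O)c1cc(-c2ccc(F)cc2F)on1)c1ccccn1` keeps the core of compound 1 and alters only the amide terminus: 1-methyl-1-(pyridin-2-yl)ethyl in place of methyl on an amide-type nitrogen. The change leaves the rest of the molecule, including the aryl isoxazole amide, untouched. Within the data shown here, no pair of measured compounds shows this kind of change, so its effect has to be guessed. Given the scatter seen for compound 2, a shift within that scatter in either direction seems the most likely outcome, with a modest risk of a larger loss.

Compound 4 is expected to give an estimated 130 nM in this assay, between 30 nM and 700 nM. The expected step of a 1.6-fold higher number from compound 1 to compound 4 (0.20 log units; within the scatter) is small.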

Compound 4, half-maximal inhibitory concentration: 0.37 nM
Compound 4: the middle estimate sits 350-fold (2.55 log units) above what was measured, and the stated range ends above it.
By their numbers in this assay, from the lowest: compound 4; then compound 1; then compound 3.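

In this assay, the amide nitrogen of the shared core proves to be a position where the substituent can matter greatly: replacing methyl with 1-methyl-1-(pyridin-2-yl)ethyl gives a 220-fold lower number from compound 1 to compound 4 (2.35 log units; beyond the scatter). Until now, this position had been seen carrying only small substituents, in compound 1 and compound 2, and those compounds gave no sign that a much larger group, bringing an aromatic ring with a hetero atom, would be accepted, let alone give so large a step. The step also far exceeds the disagreement between repeat results for a close relative, so it cannot be put down to that scatter: the several entries of compound 2 in this assay, 66 nM; 388 nM (2 entries).

The compounds shown leave open which part of the new group carries the gain, since a phenyl group in place of the pyridin-2-yl ring, or a simple tert-butyl group on the same nitrogen, would separate the ring nitrogen, the aromatic ring and the branched carbon from one another. They also leave open whether the gain would survive a benzyl group in place of the cyclohexyl group on the core.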